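Swapping the amide aryl group on a shared flavonol core

The compounds below may be only part of what the source reports. "The series", "measured", "known", "first", "only" and "open" are said of these compounds alone.

Measured so far:
compound 1 `O=C(Nc1cccc(-c2oc3cc(-c4ccc(F)cc4)ccc3c(=O)c2O)c1)c1ccc(Cl)cc1` — in a functional assay on HCC1937 cells (Homo sapiens) for antiproliferative activity, read by CCK-8 assay, with a stated time of 72 h (on this read-out higher numbers stand for weaker inhibition and lower numbers for stronger inhibition), compound 1 gives 4030 nM
compound 2 `Cc1cccc(C(=O)Nc2cccc(-c3oc4cc(-c5ccc(F)cc5)ccc4c(=O)c3O)c2)c1` — in this assay compound 2 gives 8030 nM

Compound 2 sits at one end of these two numbers, but the gap to compound 1 is small: the step of a 2.0-fold higher number from compound 1 to compound 2 (0.30 log units; within the scatter) is within the scatter, so the two compounds cannot be told apart on this read-out. Both share the same core, and differ only in the aryl group attached to the amide carbonyl.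

Compound 3 `CCc1ccc(C(=O)Nc2cccc(-c3oc4cc(-c5ccc(F)cc5)ccc4c(=O)c3O)c2)cc1` keeps everything else and changes that aryl group again: 4-ethylphenyl in place of 3-methylphenyl on a carbonyl carbon. Going by the values given here, the only measured step that bears on it is the one from compound 1 to compound 2, which also exchanged one aryl group for another at this carbonyl, and that step stayed within the scatter. Nothing measured here separates one substituted phenyl on the carbonyl from another beyond the noise.

The expected step of a 1.1-fold lower number from compound 2 to compound 3 (0.06 log units; within the scatter) is therefore none beyond the scatter. Compound 3 is estimated at 7000 nM in this assay, with a range from 3000 nM to 16000 nM.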

Compound 3, half-maximal inhibitory concentration: 13200 nM
For compound 3 the middle estimate is 1.9-fold (0.28 log units) below the measured one; the measured number falls inside the stated range.
By their numbers in this assay, from the lowest: compounds 1, 2 and 3 (each within the scatter of the next, the first and the last beyond it).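

In this assay, the step of a 1.6-fold higher number from compound 2 to compound 3 (0.22 log units; within the scatter) again fails to separate two substituted phenyl groups on this carbonyl carbon, so 4-ethylphenyl and 3-methylphenyl cannot be told apart on this read-out. Going by these compounds alone, what is new is the first step at this position to clear the noise: the change of chloro to ethyl on an aromatic carbon gives a 3.3-fold higher number from compound 1 to compound 3 (0.52 log units; beyond the scatter) and is a modest difference, which shows that the group on this carbonyl is not entirely without effect on the read-out, even though compound 2 lies within the scatter of both neighbours. Nothing available here accounts for this difference between chloro and ethyl.

The 3-methylphenyl of compound 2 and the 4-ethylphenyl of compound 3 differ in both the chain and its place on the ring, so the compounds shown cannot say which of the two matters. From the compounds shown here alone, it also remains open how a plain phenyl, or a phenyl carrying an amine or a carboxylic acid in place of the ethyl, would read in this assay on the shared core.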